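Swapping the acyl group on a piperidine amide

The source may hold more compounds than are shown below. What is called first, only, known or untested is meant among the compounds shown, and "the series" means these compounds.

Of the compounds shown here, two have been measured so far in an assay on THP-1 cells for displacement of a labelled ligand from C-C chemokine receptor type 1 (Homo sapiens); on this read-out lower numbers stand for stronger inhibition and higher numbers for weaker inhibition. Compound 1 `CC[C@@H](NC(=O)CC(C)C)C(=O)N1CCC(c2ccc(Cl)cc2)CC1` gives 152 nM. Compound 2 `CC(C)[C@@H](NC(=O)c1cccc(F)c1)C(=O)N1CCC(c2ccc(Cl)cc2)CC1` gives 24 nM, the lowest of the two numbers, and compound 1 stands next to it at a higher number, a gap that lies beyond the scatter. The step now followed goes from compound 2 to compound 3 `CC(C)CC(=O)N[C@@H](C(=O)N1CCC(c2ccc(Cl)cc2)CC1)C(C)C`, which has not yet been measured in this assay. The change is isobutyl in place of 3-fluorophenyl on a carbonyl carbon. Compound 3 therefore carries the same isobutylcarbonyl group as compound 1, while keeping the side chain of compound 2. Because compound 1 with that acyl group gives 152 nM, compound 3 is expected to lose potency, and the step of a 3.8-fold higher number from compound 2 to compound 3 (0.57 log units; beyond the scatter) is estimated to lie beyond the scatter. For compound 3 the expected value in this assay is 90 nM, with a range from 30 nM to 300 nM.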

Compound 3, half-maximal inhibitory concentration: 32 nM
Estimate against measurement, compound 3: 2.8-fold (0.45 log units) above; measured number inside the range.
By their numbers in this assay, from the lowest: compounds 2 and 3 (each within the scatter of the next); then compound 1.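

In this assay, the step for isobutyl in place of 3-fluorophenyl on a carbonyl carbon is a 1.3-fold higher number from compound 2 to compound 3 (0.12 log units; within the scatter), so with this side chain the acyl position accepts a group with no ring as well as one with an aromatic ring. Among these compounds, with the isobutylcarbonyl group held, methyl in place of hydrogen on a saturated chain carbon bound to two saturated chain carbons gives a 4.8-fold lower number from compound 1 to compound 3 (0.68 log units; beyond the scatter), and this is the one single-place step here that lies beyond the scatter. Nothing measured bears on why these two steps differ in size.

From the compounds shown here alone, it remains open how an amine, a carboxylic acid or a longer chain would read on this carbonyl carbon. Also open, going by these compounds, is whether 3-fluorophenyl and isobutyl would stand as close together on the side chain of compound 1.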